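Shortening a side chain on a shared pyrrolopyrimidine-free core

This account rests on a few compounds, and the source may have more. Where it says the series, first, only, none or still open, it means among the compounds named here.

Measured so far:
compound 1 `CN(C)C(=O)c1cc2cnc(Nc3ccc(C(=O)NCCCCN=C=S)cc3)nc2n1C1CCCC1` — 102%
compound 2 `CN(C)C(=O)c1cc2cnc(Nc3ccc(NC(=O)CCCCN=C=S)cc3)nc2n1C1CCCC1` — 102%

In a functional assay on A549 cells (Homo sapiens) for inhibition, read by CCK-8 assay, with a stated time of 72 h, tested at 10 uM (on this read-out lower numbers stand for a weaker effect and higher numbers for a stronger effect at the one concentration tested), compound 2 gives 102%, level with compound 1, and no change at the digits printed from compound 1 to compound 2 (within the scatter). Both values sit at the top of what this read-out can report, so the swap of one side group for the other shows no difference at all.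

Compound 3 `CN(C)C(=O)c1cc2cnc(Nc3ccc(N=C=S)cc3)nc2n1C1CCCC1` arises from compound 2 by a group of 3 heavy atoms (1 carbon, 1 nitrogen, 1 sulfur; no ring) in place of a group of 10 heavy atoms (6 carbon, 2 nitrogen, 1 oxygen, 1 sulfur; no ring), on an aromatic carbon. Among the measured compounds shown here, the one measured step, from compound 1 to compound 2, kept the size of the side group constant and changed only its inner order; no step so far removes most of the side group. The change to compound 3 is therefore outside what has been tested, and the measured step offers only weak guidance. Compound 3 is expected to remain strongly active, with a step of about a number 10 percentage points lower from compound 2 to compound 3 (within the scatter), estimated at 92% with a range from 60% to 105%.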

Compound 3, a percentage reported as inhibition, at one concentration (the size of the read-out at that concentration, not a potency): 97.9%
Compound 3: the middle estimate sits 5.9 percentage points below what was measured; measured number inside the range.
By their numbers in this assay, from the lowest: compounds 3, 1 and 2 (each within the scatter of the next).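

In this assay, the group of 10 heavy atoms on this aromatic carbon, para to a large group, can give way to a group of only 3 heavy atoms with a number 4.1 percentage points lower from compound 2 to compound 3 (within the scatter). The same holds against the other long side group, with a number 4.1 percentage points lower from compound 1 to compound 3 (within the scatter), so at this single concentration neither long chain, nor the hydrogen-bond donor it carries, is needed for the effect. No measurement is at hand that would explain this result.

All three compounds sit so close together at one concentration that any differences in potency between them stay hidden, and lower concentrations could reveal whether the shorter group truly matches the longer ones. From the compounds shown here alone, it also remains open whether the effect would persist with an amine or a carboxylic acid at this position.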